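Aryl swap on the piperazine of an isatin thiosemicarbazone

This account rests on a few compounds, and the source may have more. Where it says the series, first, only, none or still open, it means among the compounds named here.

Compound 1, `O=C1Nc2ccccc2/C1=N/NC(=S)N1CCN(c2ccccc2)CC1`, gives 11100 nM in a functional assay on HCT-116 cells (Homo sapiens) for inhibition, read by MTT assay, with a stated time of 72 h; a higher number here means a weaker inhibitor, a lower number a stronger inhibitor.
Compound 2, `Cc1ccc2c(c1)/C(=N/NC(=S)N1CCN(c3ccccc3)CC1)C(=O)N2`, gives 9480 nM in this assay.
Compound 3, `Cc1ccc(N2CCN(C(=S)N/N=C3\C(=O)Nc4ccc(Cl)cc43)CC2)cc1`, gives 6390 nM in this assay.

Compound 3 has the lowest number of the three, but its distance to compound 2 and to compound 1 is within the scatter, so the three compounds cannot be told apart on these numbers. Within the data shown here, the only step measured between two compounds that differ in one place is a 1.2-fold lower number from compound 1 to compound 2 (0.07 log units; within the scatter), which also lies within the scatter.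

Compound 4, `O=C1Nc2ccc(Cl)cc2/C1=N/NC(=S)N1CCN(c2ccccc2F)CC1`, differs from compound 3 by 2-fluorophenyl in place of 4-methylphenyl on an amine nitrogen in a ring. Among the measured compounds shown here, no measured pair shows this change; the single measured step concerns a methyl on an aromatic carbon of the shared core, not the group on the ring nitrogen, and it was small. With nothing pointing either way, no change beyond the scatter in this assay is expected from compound 3 to compound 4.

Compound 4 is therefore estimated at 7000 nM, with a range from 3000 nM to 16000 nM, an expected step of a 1.1-fold higher number from compound 3 to compound 4 (0.04 log units; within the scatter).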

Compound 4, half-maximal inhibitory concentration: 8290 nM
Compound 4: the middle estimate sits 1.2-fold (0.07 log units) below what was measured, within the range that was stated.
By their numbers in this assay, from the lowest: compounds 3, 4, 2 and 1 (each within the scatter of the next).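

In this assay, among these compounds, the pair of compound 3 and compound 4 is the first to change the aryl group on the amine nitrogen in a ring, where the earlier step touched only a methyl on an aromatic carbon of the shared core. The exchange of 4-methylphenyl for 2-fluorophenyl gives a 1.3-fold higher number from compound 3 to compound 4 (0.11 log units; within the scatter), so at this position these two substituted phenyl groups cannot be told apart, with the chloro-bearing core held constant. No measurement bears on why the step is this small.

Both groups have 7 heavy atoms and one six-membered aromatic ring of carbon only, and the step changes both the substituent and where it sits on that ring, so a 4-fluorophenyl group would be needed to separate the two changes. The compounds shown also leave open whether anything other than a substituted phenyl group on this nitrogen, such as a benzyl group, a pyridine ring or a chain ending in an amine or a carboxylic acid, would move the number beyond the scatter.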